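Naphthalen-2-yl in place of 4-chlorophenyl: outlook for compound 4

The source may report more compounds than this note shows. Statements on the series, on what has been measured and on what is new or still open speak of the compounds shown alone.

Three compounds of the series have numbers in a functional assay on A549 cells (Homo sapiens) for antiproliferative activity, with a stated time of 5 days; on this read-out lower numbers stand for stronger inhibition and higher numbers for weaker inhibition. Compound 1 `O=C1C=CC2(C=C1)OCC(=O)N2c1nc(-c2ccc3ccccc3c2Br)nn1-c1ccccc1` gives 100 nM, compound 3 `CC1OC2(C=CC(=O)C=C2)N(c2nc(-c3cccc4ccccc34)nn2-c2ccccc2)C1=O` gives 180 nM, and compound 2 `O=C1C=CC2(C=C1)OCC(=O)N2c1nc(-c2ccc3ccccc3c2)nn1-c1ccc(Cl)cc1` gives 400 nM, the highest of the three: compound 3 lies nearest, with a number beyond the scatter below it, and compound 1 lies furthest, also beyond the scatter. Compound 4 `O=C1C=CC2(C=C1)OCC(=O)N2c1nc(-c2ccc3ccccc3c2)nn1-c1ccc2ccccc2c1` differs from compound 2 in one place: naphthalen-2-yl in place of 4-chlorophenyl on an aromatic nitrogen. Among the compounds with values here, no pair of measured compounds shows this change on its own, so the size of the step is open; compounds 1 and 3 carry a different group at that aromatic nitrogen and both give lower numbers than compound 2, but other parts of those compounds differ too. A modest step downward, near the edge of the scatter, is expected, a 1.6-fold lower number from compound 2 to compound 4 (0.20 log units; within the scatter). Compound 4 is estimated at 250 nM, between 80 nM and 800 nM.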

Compound 4, half-maximal inhibitory concentration: 250 nM
For compound 4 middle estimate and measured number coincide at the digits printed; the measured number falls inside the stated range.
By their numbers in this assay, from the lowest: compounds 1, 3, 4 and 2 (each within the scatter of the next, the first and the last beyond it).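

In this assay, the change at this aromatic nitrogen can now be read on its own: a 1.6-fold lower number from compound 2 to compound 4 (0.20 log units; within the scatter), so the second six-membered aromatic ring of carbon only and the loss of chlorine leave the number within the scatter of compound 2. The position therefore accepts naphthalen-2-yl, with 10 heavy atoms against 7 for 4-chlorophenyl. No measurement at hand explains this outcome.

Still open, on these data alone, is how this position responds to a 4-aminophenyl or 4-carboxyphenyl group. Also open, as far as these compounds go, is what unsubstituted phenyl gives here alongside the unsubstituted naphthalen-2-yl of compound 2.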